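From Methyl to 4-Hydroxycyclohexyl on Compound 3

A few compounds are considered here, and "the series" means these few. Any claim that something is new, unique, unknown or untested is made for them only; others in the source may bear on it.

In a physicochemical assay for solubility (on this read-out lower numbers stand for lower solubility and higher numbers for higher solubility), compound 3 `CN1CCN(C(=O)c2nc3c(C(F)(F)F)cc(-c4ccoc4)cn3c2Cl)CC1=O` stands at a limit (> 500000 nM). Compound 2 `O=C(c1nc2c(C(F)(F)F)cc(-c3ccoc3)cn2c1Cl)N1CCC(N2CCCC2=O)CC1` stands at a limit too (> 500000 nM) and carries a large group. Compound 1 `O=C(c1nc2c(C(F)(F)F)cc(-c3ccoc3)cn2c1Cl)N1CCC(c2cccs2)C1` stands at a limit at the low end (< 15000 nM). Going by the values given here, the one measured step (an at least 33-fold higher number from compound 1 to compound 3 (1.52 log units; beyond the scatter)) is large and beyond the scatter, but it exchanges the whole group on the carbonyl carbon. Compound 4 `O=C(c1nc2c(C(F)(F)F)cc(-c3ccoc3)cn2c1Cl)N1CCN([C@H]2CC[C@@H](O)CC2)C(=O)C1` has 4-hydroxycyclohexyl in place of methyl on an amide-type nitrogen in a ring. A moderate fall in this assay is therefore expected, smaller than that measured step (an at least 33-fold higher number from compound 1 to compound 3 (1.52 log units; beyond the scatter)). The expected change is modest (an at least 2.5-fold lower number from compound 3 to compound 4 (0.39 log units; beyond the scatter)). For compound 4 the estimated value is 200000 nM (expected range 40000 nM to 500000 nM).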

Compound 4, solubility: > 500000 nM
Compound 4: a limit, no number (the forecaster's own chance of this, stated with the estimate: 40%); middle value at least 2.5-fold (0.39 log units) away from the limit.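

In this assay compound 4 gives > 500000 nM, which is a limit. Compound 3 stands at a limit too, > 500000 nM, and the step between the two cannot be read. As far as these compounds go, whether 4-hydroxycyclohexyl in place of methyl changes the read-out at all stays open.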